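This account rests on a few compounds, and the source may have more. Where it says the series, first, only, none or still open, it means among the compounds named here.

Working notes on the series, read in a functional assay on SW-620 cells (Homo sapiens) for cytotoxicity, read by colorimetric assay; a higher number here means a weaker inhibitor, a lower number a stronger inhibitor. Of the compounds shown here, three have numbers so far: compound 1 `O=C(/C=C/c1ccc(CN2C(=O)/C(=C3\Nc4ccccc4\C3=N/O)c3cccc(Cl)c32)cc1)NO` gives 60 nM, compound 2 `Cc1ccc2c(c1)/C(=C1/Nc3ccccc3/C1=N\O)C(=O)N2Cc1ccc(/C=C/C(=O)NO)cc1` gives 50 nM and compound 3 `COc1ccc2c(c1)/C(=C1/Nc3ccccc3/C1=N\O)C(=O)N2Cc1ccc(/C=C/C(=O)NO)cc1` gives 40 nM. The number for compound 2 lies within the scatter of the other two, so these three compounds cannot be ranked in this assay.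

The next compound is compound 4 `Cc1ccc2c(c1)/C(=C1/Nc3ccccc3/C1=N\O)C(=O)N2Cc1ccc(C(=O)NO)cc1`, which is compound 2 with one change: hydroxycarbamoyl in place of 2-(hydroxycarbamoyl)ethenyl on an aromatic carbon. In words, hydroxycarbamoyl stands in place of 2-(hydroxycarbamoyl)ethenyl on an aromatic carbon, para to a large group.

Among the measured compounds shown here, the only measured step between single-place neighbours is a 1.3-fold lower number from compound 2 to compound 3 (0.10 log units; within the scatter). It swaps methoxy for methyl on the core and leaves 2-(hydroxycarbamoyl)ethenyl untouched, so it bears on the new change only weakly. All three measured compounds carry 2-(hydroxycarbamoyl)ethenyl, and the data therefore hold no direct measure of removing it. The flat numbers for core changes say nothing about whether this group can be altered as freely.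

A move to a higher number, beyond the scatter, is still expected in this assay, though with low confidence. The estimated step is a 3.6-fold higher number from compound 2 to compound 4 (0.56 log units; beyond the scatter). For compound 4 the expected value is 180 nM, with an estimated range from 50 nM to 700 nM.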

Compound 4, half-maximal inhibitory concentration: 30 nM
The estimate for compound 4 lay 6.0-fold (0.78 log units) above the measured number; the whole stated range lies above it.
By their numbers in this assay, from the lowest: compounds 4, 3, 2 and 1 (each within the scatter of the next).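

In this assay, replacing 2-(hydroxycarbamoyl)ethenyl with hydroxycarbamoyl gives a 1.7-fold lower number from compound 2 to compound 4 (0.22 log units; within the scatter), so the two compounds cannot be told apart. Among the compounds shown here, the earlier compounds differed only on the core, and this is the first reading of a change on the aromatic carbon para to a large group: on the core of compound 2, the ethenyl link can go without a step beyond the scatter, and the number stays level with those of the three earlier compounds. Nothing on hand accounts for this result.

As far as these compounds go, whether the same exchange is equally tolerated on the core of compound 1 or compound 3 remains open, as a single step on one core cannot establish a rule for the series. Also open, from the compounds shown here alone, is how far this position tolerates change, in particular whether a carboxylic acid in place of hydroxycarbamoyl, or a longer saturated chain ending in hydroxycarbamoyl, would also stay within the scatter of compound 2.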